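The source may report more compounds than this note shows. Statements on the series, on what has been measured and on what is new or still open speak of the compounds shown alone.

In a functional assay on A549 cells (Homo sapiens) for cytotoxicity, read by MTT assay, with a stated time of 72 h (on this read-out higher numbers stand for weaker inhibition and lower numbers for stronger inhibition), compound 1 `COc1ccc(OC)c(/C=N/NC(=O)Nc2ccc(Oc3ccnc(-c4nncn4CCN(C)C)c3)c(F)c2)c1` gives 1950 nM. Compound 2 `CN(C)CCn1cnnc1-c1cc(Oc2ccc(NC(=O)N/N=C/c3ccc(O)c(O)c3)cc2F)ccn1` reaches only a limit of the assay, > 100000 nM, with no number behind it. Compound 3 `COc1cc(/C=N/NC(=O)Nc2ccc(Oc3ccnc(-c4nncn4CCN(C)C)c3)c(F)c2)cc(OC)c1OC` likewise stops at a limit, > 100000 nM. Both of these sit at the limit of > 100000 nM in this assay, at which 2 of the 3 values shown sit, so compound 2 stands at the edge of what the assay reports and cannot be placed more closely than that. The measured steps both start from compound 1: an at least 51-fold higher number from compound 1 to compound 2 (1.70 log units; beyond the scatter) and an at least 51-fold higher number from compound 1 to compound 3 (1.70 log units; beyond the scatter). Between the two limits, a step that the two limits leave unreadable from compound 2 to compound 3. Compound 4 `CN(C)CCn1cnnc1-c1cc(Oc2ccc(NC(=O)N/N=C/c3ccccc3)cc2F)ccn1` differs from compound 2 in one place: phenyl in place of 3,4-dihydroxyphenyl on a carbon with a double bond to nitrogen. Going by the values given here, no measured step exchanges 3,4-dihydroxyphenyl for phenyl, so the two steps from compound 1 show only how strongly this position moves the number, not which way this particular change goes. The step is expected to be an at least 5.0-fold lower number from compound 2 to compound 4 (0.69 log units; beyond the scatter), with its direction uncertain. Compound 4 is therefore expected to give roughly 20000 nM, somewhere between 2000 nM and 150000 nM.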

Compound 4, half-maximal inhibitory concentration: 1860 nM
Compound 4: middle estimate off by 11-fold (1.03 log units), on the high side; the whole stated range lies above it.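

Phenyl and 2,5-dimethoxyphenyl turn out to be interchangeable at this position, with a 1.0-fold lower number from compound 1 to compound 4 (0.02 log units; within the scatter). Going by these compounds alone, the bare phenyl ring therefore keeps the activity, and the loss seen earlier belongs to the two other rings, as an at least 53-fold lower number from compound 2 to compound 4 (1.73 log units; beyond the scatter) and an at least 53-fold lower number from compound 3 to compound 4 (1.73 log units; beyond the scatter) show, giving this change a clear direction that the earlier compounds could not. These two steps are only minimum sizes, because compound 2 and compound 3 each give a limit and not a number: the limit of > 100000 nM in this assay, at which 2 of the 4 values shown sit.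

The compounds shown leave open whether a phenyl ring carrying a single hydroxyl or a single methoxy group stays close to compound 4 or falls to that limit. They also leave open how an amine or a carboxylic acid on this ring would behave.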